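The compounds below may be only part of what the source reports. "The series", "measured", "known", "first", "only" and "open" are said of these compounds alone.

In a functional assay on HCT-116 cells (Homo sapiens), read by MTT assay, with a stated time of 72 h (on this read-out higher numbers stand for weaker inhibition and lower numbers for stronger inhibition), compound 2 `CNc1ncnc2c1c(-c1cccs1)cn2[C@@H]1O[C@H](CO)[C@@H](O)[C@H]1O` gives only a limit, > 20000 nM, and not a measured number. Compound 1 `CN(C)c1ncnc2c1c(-c1ccoc1)cn2[C@@H]1O[C@H](CO)[C@@H](O)[C@H]1O` likewise reaches only a limit in this assay, > 20000 nM. Both values shown therefore sit at the limit of > 20000 nM in this assay, at which 2 of the 2 values shown sit, so compound 2 stands at the edge of what this assay reports, with nothing to separate it from compound 1. Compound 3 `CN(C)c1ncnc2c1c(-c1cccs1)cn2[C@@H]1O[C@H](CO)[C@@H](O)[C@H]1O` differs from compound 2 in one place: methyl in place of hydrogen on a nitrogen on an aromatic ring. Compound 1 already carries the dimethylamino group and still returns only a limit in this assay. On that basis the change is not expected to bring compound 3 into the measurable range; the expected step is a step that the limit leaves unreadable from compound 2 to compound 3, none beyond the scatter. Compound 3 is expected to give about 30000 nM, between 10000 nM and 100000 nM, most probably again reported only as a limit.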

Compound 3, half-maximal inhibitory concentration: > 20000 nM
Compound 3: only a limit was reported; the forecaster's own chance of this, stated with the estimate: 85%; the middle value is on the limit's open side.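

Compound 3 joins compound 1 and compound 2 at the same limit, so no step among these compounds can be read from this assay: the limit of > 20000 nM in this assay, at which 3 of the 3 values shown sit.

What the compounds shown leave open is how far any of them lies past that limit, and whether the methyl or the ring change alters activity at all.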